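The source may hold more compounds than are shown below. What is called first, only, known or untested is meant among the compounds shown, and "the series" means these compounds.

Compound 1 `COc1ccc(C2CC(Nc3nc4ccc([N+](=O)[O-])cc4s3)=NN2C(C)=O)cc1`: 145 umol/kg
Compound 2 `CC(=O)N1N=C(Nc2nc3ccc([N+](=O)[O-])cc3s2)CC1c1ccc(O)cc1`: 162 umol/kg

In a functional assay on the whole organism (Hindlimb, strain albino) with Mus musculus as the target, in the maximal electroshock model, with a stated time of 0.5 h (a higher number here means that more compound is needed for the effect, a lower number that less compound is needed), compound 2 gives 162 umol/kg, within the scatter of compound 1 at 145 umol/kg. Compound 3 `CC(=O)N1N=C(Nc2nc3ccccc3s2)CC1c1ccc(O)cc1` has hydrogen in place of nitro on an aromatic carbon. Going by the values given here, the only measured step, a 1.1-fold higher number from compound 1 to compound 2 (0.05 log units; within the scatter), is a change elsewhere, hydrogen in place of methyl on an oxygen on an aromatic ring, so no measured step tests the nitro group. With no evidence for a direction, the expected change is only a 1.1-fold higher number from compound 2 to compound 3 (0.05 log units; within the scatter), which is no real shift beyond the scatter. For compound 3 the estimated value is 180 umol/kg, with an expected range of 80 umol/kg to 400 umol/kg.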

Compound 3, dose for half-maximal effect: 249 umol/kg
For compound 3 the middle estimate is 1.4-fold (0.14 log units) below the measured one; low and high end bracket the measured number.
By their numbers in this assay, from the lowest: compounds 1, 2 and 3 (each within the scatter of the next).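

In this assay, hydrogen in place of nitro gives a 1.5-fold higher number from compound 2 to compound 3 (0.19 log units; within the scatter) and so provides the first measured test of this position, where the change stays within the scatter. Compound 3 still has a measured dose without the nitro group, so a measurable effect in this model does not require that group on the shared core. Nothing available bears on the reason for the size of this step.

From the compounds shown here alone, whether an amine, a carboxylic acid or a chlorine atom at this aromatic carbon would also stay within the scatter remains open. Whether the same change would read alike on compound 1 is open as well.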